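A few compounds are considered here, and "the series" means these few. Any claim that something is new, unique, unknown or untested is made for them only; others in the source may bear on it.

Two compounds that share a core have been examined in an assay on COS-7 cells for inhibition of patatin-like phospholipase domain-containing protein 2 (Mus musculus); on this read-out lower numbers stand for stronger inhibition and higher numbers for weaker inhibition. Compound 1, `CCOc1ccc(-c2cccc(S(=O)(=O)NC)c2)cc1`, gives 200000 nM in this assay. Compound 2, `CCOc1ccc(-c2cccc(C(=O)OCC(F)(F)F)c2)cc1`, gives 120000 nM in this assay. Of the two numbers shown, compound 2 has the lower one, but its only neighbour, compound 1, lies within the usual scatter of it, so the two compounds cannot be set apart on these data.

The next compound, compound 3, is `CCOc1ccc(-c2cccc(C(=O)N3CCCC3)c2)cc1`. It differs from compound 2 in one place: pyrrolidin-1-yl in place of 2,2,2-trifluoroethoxy on a carbonyl carbon. Among the compounds with values here, no pair of measured compounds shows this kind of exchange, so there is no measured step to lean on; the two numbers seen so far simply show that both compounds are weak in this assay.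

Given that, a shift in either direction would be a guess, and the expected step from compound 2 to compound 3 is a 1.2-fold lower number from compound 2 to compound 3 (0.08 log units; within the scatter), essentially none beyond the scatter. Compound 3 is therefore estimated at 100000 nM, with a range from 30000 nM to 400000 nM in this assay.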

Compound 3, half-maximal inhibitory concentration: 160000 nM
Compound 3: middle estimate off by 1.6-fold (0.20 log units), on the low side, within the range that was stated.
By their numbers in this assay, from the lowest: compounds 2, 3 and 1 (each within the scatter of the next).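

Within the data shown here, exchanging 2,2,2-trifluoroethoxy for pyrrolidin-1-yl on the carbonyl carbon gives a 1.3-fold higher number from compound 2 to compound 3 (0.12 log units; within the scatter) in this assay and so brings a five-membered ring to this place for the first time, yet the read-out cannot tell the two compounds apart. The second step, with (pyrrolidin-1-yl)carbonyl in place of methylsulfamoyl on an aromatic carbon, gives a 1.3-fold lower number from compound 1 to compound 3 (0.10 log units; within the scatter) and likewise separates nothing, so all three groups seen at this place leave the compounds indistinguishable, even though the exchange from compound 1 replaces the whole group attached to the aromatic carbon. Nothing available here explains why these exchanges leave the number within the scatter.

On these data alone, what stays open is whether any group at this place can move the number beyond the scatter, for example a carboxylic acid, a piperazine ring in place of the pyrrolidine or a longer chain on the carbonyl carbon. As far as these compounds go, it also remains unknown whether changes elsewhere on the shared core would have more effect than the exchanges seen so far.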